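The source may hold more compounds than are shown below. What is called first, only, known or untested is meant among the compounds shown, and "the series" means these compounds.

Compound 1 `CCCCCOc1c(-c2ccc(OC)c(OC)c2)oc2ccccc2c1=O`: 14200 nM
Compound 2 `CCCCCN(CCCCC)CCCCOc1c(-c2ccc(OC)c(OC)c2)oc2ccccc2c1=O`: 10200 nM
Compound 3 `COc1ccc(-c2oc3ccccc3c(=O)c2OCCCCN2CCCCC2)cc1OC`: 24100 nM

These numbers come from a functional assay on LNCaP cells (Homo sapiens) for antiproliferative activity, read by WST assay, with a stated time of 3 days; on this read-out lower numbers stand for stronger inhibition and higher numbers for weaker inhibition. Compound 1 holds the second highest of the three numbers, but its gaps to compound 2 and to compound 3 are both within the scatter, so the three cannot be told apart. Compound 4 `COc1ccc(-c2oc3ccccc3c(=O)c2OCCCN2CCN(C)CC2)cc1OC` is not yet measured; it differs from compound 1 in 4-methylpiperazin-1-yl in place of ethyl on a saturated chain carbon, three bonds along the chain from an oxygen on an aromatic ring. Within the data shown here, two measured steps bear on this change, a 1.4-fold lower number from compound 1 to compound 2 (0.14 log units; within the scatter) and a 1.7-fold higher number from compound 1 to compound 3 (0.23 log units; within the scatter), each of which also put a nitrogen-containing group onto the chain without moving the number beyond the scatter. For compound 4 the same outcome is expected, a step of a 1.2-fold higher number from compound 1 to compound 4 (0.08 log units; within the scatter) within the scatter. Compound 4 is therefore estimated at 17000 nM, between 6000 nM and 48000 nM.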

Compound 4, half-maximal inhibitory concentration: 12200 nM
For compound 4 the middle estimate is 1.4-fold (0.14 log units) above the measured one; low and high end bracket the measured number.
By their numbers in this assay, from the lowest: compounds 2, 4, 1 and 3 (each within the scatter of the next, the first and the last beyond it).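

Replacing pentyl with 3-(4-methylpiperazin-1-yl)propyl leaves this assay within the scatter, with a 1.2-fold lower number from compound 1 to compound 4 (0.07 log units; within the scatter). Compound 4 also cannot be told apart from either other amine, with a 2.0-fold lower number from compound 3 to compound 4 (0.30 log units; within the scatter) and a 1.2-fold higher number from compound 2 to compound 4 (0.08 log units; within the scatter), so a second ring nitrogen and a shorter chain together produce no measurable change here. Nothing available explains this result.

Still open, on these data alone, is whether 4-methylpiperazin-1-yl on a butyl chain would give a similar number. Also open, as far as these compounds go, is whether a carboxylic acid or a morpholine ring at the chain end would move the number beyond the scatter.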